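Quinoline-ether aryl hydrazone series: outlook for compound 3

This account rests on a few compounds, and the source may have more. Where it says the series, first, only, none or still open, it means among the compounds named here.

Measured so far:
- compound 1 `COc1ccc(/C=N/NC(=O)Nc2ccc(Oc3ccnc4cc(OCCCN5CCCCC5)c(OC)cc34)c(F)c2)cc1`: in a functional assay on MDA-MB-231 cells (Homo sapiens) for cytotoxicity, read by MTT assay, with a stated time of 72 h (a lower number here means a stronger inhibitor, a higher number a weaker inhibitor), compound 1 gives 840 nM
- compound 2 `COc1cc2c(Oc3ccc(NC(=O)N/N=C/c4ccc(C(F)(F)F)cc4)cc3F)ccnc2cc1OCCCN1CCCCC1`: in this assay compound 2 gives 1100 nM

Of the two numbers in this assay, that of compound 2 is the higher one, yet a 1.3-fold higher number from compound 1 to compound 2 (0.12 log units; within the scatter) falls within the scatter, so the two measured compounds cannot be separated on these data.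

Compound 3 `COc1cc2c(Oc3ccc(NC(=O)N/N=C/c4ccc(F)cc4Cl)cc3F)ccnc2cc1OCCCN1CCCCC1` differs from compound 2 by 2-chloro-4-fluorophenyl in place of 4-(trifluoromethyl)phenyl on a carbon with a double bond to nitrogen. Within the data shown here, the only measured step that speaks to this position is a 1.3-fold higher number from compound 1 to compound 2 (0.12 log units; within the scatter), an exchange of one substituent on the same aromatic ring, and it stayed within the scatter. Whether two ring halogens behave like a single trifluoromethyl cannot be read from one such step, and a change of this kind at the same place has not moved the number noticeably so far. The expected step is therefore a 1.1-fold lower number from compound 2 to compound 3 (0.04 log units; within the scatter), none beyond the scatter in either direction, with the range kept wide for the lack of a second reference. Compound 3 is estimated at 1000 nM, between 400 nM and 2600 nM.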

Compound 3, half-maximal inhibitory concentration: 790 nM
Compound 3: middle estimate off by 1.3-fold (0.10 log units), on the high side, and the stated range covers the measured number.
By their numbers in this assay, from the lowest: compounds 3, 1 and 2 (each within the scatter of the next).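

In this assay, the new group on the carbon with a double bond to nitrogen gives a 1.4-fold lower number from compound 2 to compound 3 (0.14 log units; within the scatter) and a 1.1-fold lower number from compound 1 to compound 3 (0.03 log units; within the scatter), so 2-chloro-4-fluorophenyl cannot be separated from either 4-(trifluoromethyl)phenyl or 4-methoxyphenyl on these data. The earlier step covered only the exchange of one substituent on the ring, whereas compound 3 carries two ring halogens and still shows no step beyond the scatter, which makes three aryl groups at this place, in compounds 1, 2 and 3, that give numbers within the scatter of one another. No measurement is available that could explain these numbers or show what, if anything, separates the three groups.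

All three groups shown are six-membered aromatic rings of carbon only, with no hydrogen-bond donors or acceptors counted and no net charge, so it remains open whether an amine or a carboxylic acid on that ring, or a longer chain in place of the ring, would give a step beyond the scatter. As far as these compounds go, the rest of the structure is the same in compounds 1, 2 and 3, so it is also open whether this lack of separation would persist with a change elsewhere on the shared core.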